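Moving a Nitrile Around the Phenyl of a Triazole Ether

This account rests on a few compounds, and the source may have more. Where it says the series, first, only, none or still open, it means among the compounds named here.

Three compounds share one core and differ only in the group carried on a phenyl ring attached to the triazole. Compound 1 `COc1ccc(/C=C\C(=O)O)c(OCc2cn(-c3cccc(C#N)c3)nn2)c1CC=C(C)C` gives 19200 nM in a functional assay on T47D cells (Homo sapiens) for cytotoxicity, read by MTT assay, with a stated time of 24 h; a higher number here means a weaker inhibitor, a lower number a stronger inhibitor. Within the data shown here, compound 2 `COc1ccc(/C=C\C(=O)O)c(OCc2cn(-c3ccccc3)nn2)c1CC=C(C)C`, with a plain phenyl, gives 34100 nM and so stands at the higher of the two numbers obtained, with compound 1 as its nearest neighbour; this gap, a 1.8-fold higher number from compound 1 to compound 2 (0.25 log units; within the scatter), is the only measured step and lies within the scatter. Compound 3 `COc1ccc(-n2cc(COc3c(/C=C\C(=O)O)ccc(OC)c3CC=C(C)C)nn2)cc1` gives "not determined" (no result reported) in this assay and so offers no number to lean on.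

Compound 4 `COc1ccc(/C=C\C(=O)O)c(OCc2cn(-c3ccccc3C#N)nn2)c1CC=C(C)C` is compound 2 with one change: cyano in place of hydrogen on an aromatic carbon. The closest guide is the step from compound 1 to compound 2, where the same group was removed at a different place and the number moved only within the scatter. The expected step of a 1.4-fold lower number from compound 2 to compound 4 (0.13 log units; within the scatter) is therefore small and of no settled direction. Compound 4 is estimated at 25000 nM, within a range from 10000 nM to 60000 nM.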

Compound 4, half-maximal inhibitory concentration: 8800 nM
Compound 4: middle estimate off by 2.8-fold (0.45 log units), on the high side; the whole stated range lies above it.
By their numbers in this assay, from the lowest: compound 4; then compounds 1 and 2 (each within the scatter of the next).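

In this assay the change from phenyl to 2-cyanophenyl gives a 3.9-fold lower number from compound 2 to compound 4 (0.59 log units; beyond the scatter) and so clears the scatter, which the step between compound 1 and compound 2 did not. The place of the nitrile on the phenyl therefore matters in this set: 2-cyanophenyl in place of 3-cyanophenyl gives a 2.2-fold lower number from compound 1 to compound 4 (0.34 log units; beyond the scatter) even though the group itself stays the same. Compound 4 thus holds the lowest number among the compounds with a result, and its steps to both others lie beyond the scatter.

On these data alone, whether an amine, a carboxylic acid or a chlorine atom at that same place would also lower the number remains open, and compound 3 offers no number to help with that question. Nothing measured here explains why the place of the nitrile makes this difference.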